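Moving a Fluorine Around the Phenyl Ring

The compounds below may be only part of what the source reports. "The series", "measured", "known", "first", "only" and "open" are said of these compounds alone.

Compound 1, `Cn1c(-c2ccccc2F)cnc1NC(=O)c1ccc(F)cc1`: > 100000 nM
Compound 2, `COc1ccc(-c2cccc(NC(=O)c3ccc(F)cc3)n2)cc1`: > 100000 nM
Compound 3, `COc1ccc(-c2cnc(NC(=O)c3ccc(C#N)cc3)n2C)cc1`: > 100000 nM

All three compounds were tested in a toxicity assay on THP-1 cells (Homo sapiens) for inhibition; a lower number here means that less compound is tolerated, a higher number that more compound is tolerated. Each of the three numbers is a limit of the assay rather than a measured value. For compound 1 this means only that the half-maximal cytotoxic concentration lies beyond the highest concentration tested. Compound 2 sits at the same limit. So does compound 3. Compound 1 therefore stands with the whole set at the limit of > 100000 nM in this assay, at which 3 of the 3 values shown sit, and no measured step between any two of these compounds exists, so nothing is yet known about how a change of structure moves the result.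

Compound 4, `Cn1c(-c2cccc(F)c2)cnc1NC(=O)c1ccc(F)cc1`, has not been measured. It differs from compound 1 in one place: 3-fluorophenyl in place of 2-fluorophenyl on an aromatic carbon. The 2-fluorophenyl group leaves and a 3-fluorophenyl group enters.

Among the compounds with values here, since every value so far is a limit, the expectation is of no step beyond the scatter, and compound 4 is expected to behave like compound 1; the estimated step is a number no higher from compound 1 to compound 4 (the limit leaves the size open). Compound 4 is therefore estimated at 100000 nM, with a range from 40000 nM to 300000 nM, and most likely the assay will again report only a limit.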

Compound 4, half-maximal cytotoxic concentration: 58000 nM
For compound 4 the middle estimate is 1.7-fold (0.24 log units) above the measured one; the measured number falls inside the stated range.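

Within the data shown here, putting 3-fluorophenyl in place of 2-fluorophenyl, on the same aromatic carbon of the shared core, gives the first step in this set that can be read at all: an at least 1.7-fold lower number from compound 1 to compound 4 (0.23 log units; that floor lies within the scatter). Going by these compounds, the result for compound 1, > 100000 nM, is a limit of the assay and not a number, so the true size of this step remains unknown and the change may be small or much larger. Among these compounds, compound 4 gives 58000 nM in this assay, the first real number in the set, so a half-maximal cytotoxic concentration can be measured for a close relative of compound 1. The other results remain limits of the assay: the limit of > 100000 nM in this assay, at which 3 of the 4 values shown sit.

The compounds shown leave open whether the fluorine itself has any bearing on the result, since a plain phenyl at this place does not appear among them, and neither does a phenyl carrying an amine or a carboxylic acid. Among the compounds shown here, they also leave open how far the number can move with a change at this position, since only this one step can be read.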